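Nitrate-Bearing Cinnamates: Hydroxy to Methoxy and Cytotoxicity

A few compounds are considered here, and "the series" means these few. Any claim that something is new, unique, unknown or untested is made for them only; others in the source may bear on it.

Compound 1 `O=C(/C=C/c1ccc(OCCCCCO[N+](=O)[O-])c(O)c1)OCCCCCO[N+](=O)[O-]`: in a functional assay on A549 cells (Homo sapiens) for cytotoxicity, read by resazurin assay, with a stated time of 72 h (a higher number here means a weaker inhibitor, a lower number a stronger inhibitor), compound 1 gives 450 nM.
Compound 2 `O=C(/C=C/c1ccc(OCCCCCCO[N+](=O)[O-])c(O)c1)OCCCCCCO[N+](=O)[O-]`: compound 2 gives only a limit, > 50000 nM.
Compound 3 `COc1cc(/C=C/C(=O)OCCCCCO[N+](=O)[O-])ccc1OCCCCCO[N+](=O)[O-]`: compound 3 gives only a limit, > 50000 nM.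

Compound 4 `COc1cc(/C=C/C(=O)OCCCCCCO[N+](=O)[O-])ccc1OCCCCCCO[N+](=O)[O-]` has not been measured. Compound 3 differs from compound 1 by methyl in place of hydrogen on an oxygen on an aromatic ring, and this change gives an at least 110-fold higher number from compound 1 to compound 3 (2.04 log units; beyond the scatter). Compound 4 differs from compound 2 by methyl in place of hydrogen on an oxygen on an aromatic ring, the same change at the same place. The difference between the cores of compound 1 and compound 2 is not broken down here. Compound 2 already sits at the limit of > 50000 nM in this assay, at which 2 of the 3 values shown sit, so the number cannot be seen to rise further. For compound 4 the expected step is a step that the limit leaves unreadable from compound 2 to compound 4, resting on the earlier step in this assay and on compound 2 standing at the limit of > 50000 nM in this assay, at which 2 of the 3 values shown sit. Compound 4 is therefore expected to give 100000 nM, most likely again only a limit, somewhere between 50000 nM and 500000 nM.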

Compound 4, half-maximal inhibitory concentration: > 50000 nM
Compound 4: no number, only a limit; the forecaster's own chance of this, stated with the estimate: 90%; the middle value lies beyond the limit too.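

Compound 2 and compound 4 both give only a limit, not a number, so no step can be read between them: the limit of > 50000 nM in this assay, at which 3 of the 4 values shown sit.

The compounds shown leave open whether changing hydroxy to methoxy on the core of compound 2 has any effect.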